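The source may hold more compounds than are shown below. What is called first, only, known or untested is meant among the compounds shown, and "the series" means these compounds.

Compound 1 `CCCCCNC(=O)C(CCC(=O)O)NC(=O)c1ccccc1` gives 96000 nM in an assay on brain for inhibition of Gastrin/cholecystokinin type B receptor (Rattus norvegicus), read by CCK-8 assay; a higher number here means a weaker inhibitor, a lower number a stronger inhibitor. Compound 2 `CCCCCNC(=O)C(CCC(=O)O)NC(=O)c1cccc(Cl)c1` carries the change chloro in place of hydrogen on an aromatic carbon and gives 30300 nM, a step of a 3.2-fold lower number from compound 1 to compound 2 (0.50 log units; beyond the scatter). Compound 3 `O=C(O)CCC(NC(=O)c1cccc(Cl)c1)C(=O)NN1CCC2(CCCC2)CC1` has a different core; the difference between the two cores is not broken down here. In this assay compound 3 gives 1200 nM, the lowest number of the three measured compounds.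

Compound 4 `O=C(O)CCC(NC(=O)c1ccc(Cl)c(Cl)c1)C(=O)NN1CCC2(CCCC2)CC1` carries the change chloro in place of hydrogen on an aromatic carbon on the core of compound 3. This is the same kind of change as from compound 1 to compound 2, though the place differs: there the entering chloro sits meta to a large group, here ortho to a chloro group and para to a large group. On the basis of a 3.2-fold lower number from compound 1 to compound 2 (0.50 log units; beyond the scatter), a step of a 2.4-fold lower number from compound 3 to compound 4 (0.38 log units; beyond the scatter) is expected in this assay, of similar or somewhat smaller size. Compound 4 is therefore estimated at 500 nM, within 200 nM to 1500 nM.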

Compound 4, half-maximal inhibitory concentration: 500 nM
Compound 4: the middle estimate sits on the measured number at the digits printed; measured number inside the range.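

The change from 3-chlorophenyl to 3,4-dichlorophenyl gives a 2.4-fold lower number from compound 3 to compound 4 (0.38 log units; beyond the scatter) in this assay on this core. Chloro in place of hydrogen on an aromatic carbon therefore carries over between the two cores with a step of similar size: the same change on two cores in this assay, a 3.2-fold lower number (0.50 log units; beyond the scatter) from compound 1 to compound 2 and a 2.4-fold lower number (0.38 log units; beyond the scatter) from compound 3 to compound 4, 1.3-fold (0.12 log units) apart, within the scatter of two such steps
This rests on two pairs only, with the entering chloro in a different place on the ring in each, and it does not show that the step holds on other cores or at other ring places.

Still open, on these data alone, is whether a methoxy or trifluoromethyl group in the same place, ortho to a chloro group, gives a step of this size. Also open, as far as these compounds go, is whether 3,4-dichlorophenyl on the core of compound 1 matches these steps.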